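A few compounds are considered here, and "the series" means these few. Any claim that something is new, unique, unknown or untested is made for them only; others in the source may bear on it.

Measured compounds:
compound 1 `O=C(OCCc1ccc(Cl)c(Cl)c1)N(c1ccccc1)C1CN2CCC1CC2`, 80 nM
compound 2 `COc1ccc(COC(=O)N(c2ccccc2)C2CN3CCC2CC3)cc1`, 470 nM

For the measured compounds named here, in an assay on CHO cells for displacement of a labelled ligand from muscarinic acetylcholine receptor M5 (Homo sapiens), read by scintillation counting, with a stated time of 2 h (a lower number here means a stronger inhibitor, a higher number a weaker inhibitor), compound 1 gives 80 nM and stands lowest of the two numbers; compound 2 gives 470 nM, and the one measured step is a 5.9-fold higher number from compound 1 to compound 2 (0.77 log units; beyond the scatter), a modest move beyond the scatter when 4-methoxyphenyl replaces 3,4-dichlorobenzyl on the saturated chain carbon bound to the oxygen next to the carbonyl.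

Compound 3 `COc1ccc(CCCOC(=O)N(c2ccccc2)C2CN3CCC2CC3)cc1F` is not yet measured. It differs from compound 1 by 3-fluoro-4-methoxybenzyl in place of 3,4-dichlorophenyl on a saturated chain carbon, two bonds along the chain from an oxygen next to a carbonyl group. Going by the values given here, this change shares with the step from compound 1 to compound 2 the loss of the two chlorines and the arrival of a methoxy group on the aromatic ring, while the chain between the ring and the ester oxygen is kept long; the fluorine has no measured counterpart. Among the compounds with values here, only the step from compound 1 to compound 2 bears on it, so a move in this assay of the same direction and roughly similar size is expected, giving a 4.4-fold higher number from compound 1 to compound 3 (0.64 log units; beyond the scatter). Compound 3 is therefore estimated at 350 nM, with a range from 120 nM to 1000 nM.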

Compound 3, inhibition constant: 260 nM
Estimate against measurement, compound 3: 1.3-fold (0.13 log units) above, and the stated range covers the measured number.
By their numbers in this assay, from the lowest: compound 1; then compounds 3 and 2 (each within the scatter of the next).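

In this assay, 3-fluoro-4-methoxybenzyl in place of 3,4-dichlorophenyl on a saturated chain carbon, two bonds along the chain from an oxygen next to a carbonyl group, gives a 3.3-fold higher number from compound 1 to compound 3 (0.51 log units; beyond the scatter). This is a second change that removes both chlorines and brings in a methoxy group, and again the number rises beyond the scatter, with neither compound 2 nor compound 3 going against that pattern among the three compounds. Nothing measured here accounts for the rise.

The step alters the chain and the ring substituents together, so the share of the methoxy group, the fluorine and the chain in it cannot be told apart. As far as these compounds go, how an amine or a carboxylic acid on this ring would read also remains open.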